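The source may hold more compounds than are shown below. What is called first, only, known or untested is meant among the compounds shown, and "the series" means these compounds.

Measured so far in a functional assay on HepG2 cells (Homo sapiens) for antiproliferative activity, read by MTT assay, with a stated time of 48 h; on this read-out higher numbers stand for weaker inhibition and lower numbers for stronger inhibition:
- compound 1 `CCN(CC)CCNC(=O)c1ccc(C(CC)(CC)c2ccc(OCCC(O)(CC)CC)c(C)c2)n1CC`: 230 nM
- compound 2 `CCn1c(C(=O)N(CCC#N)CCC#N)ccc1C(CC)(CC)c1ccc(OCCC(O)(CC)CC)c(C)c1`: 46300 nM
- compound 3 `C#CCCOC(=O)c1ccc(C(CC)(CC)c2ccc(OCCC(O)(CC)CC)c(C)c2)n1CC`: only a limit of the assay, > 50000 nM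

Compound 3 therefore stands at the limit of > 50000 nM in this assay, at which 1 of the 3 values shown sits, with no number of its own. The step to compound 4 `CCn1c(C(=O)N(C)CCO)ccc1C(CC)(CC)c1ccc(OCCC(O)(CC)CC)c(C)c1` changes only the group on the carbonyl carbon: (2-hydroxyethyl)(methyl)amino in place of (but-3-yn-1-yl)oxy on a carbonyl carbon. Bearing on it are an at least 210-fold higher number from compound 1 to compound 3 (2.33 log units; beyond the scatter) and a 200-fold higher number from compound 1 to compound 2 (2.30 log units; beyond the scatter), both large, whereas an at least 1.0-fold higher number from compound 2 to compound 3 (0.03 log units; that floor lies within the scatter) is a floor inside the scatter. Compound 2, the other tertiary carboxamide lacking the (2-(diethylamino)ethyl)amino group, comes out near the limit, so for compound 4 the expected step is an at least 1.6-fold lower number from compound 3 to compound 4 (0.22 log units; that floor lies within the scatter), not clearly beyond the scatter. Compound 4 is estimated at 30000 nM, within 8000 nM to 60000 nM.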

Compound 4, half-maximal inhibitory concentration: 510 nM
For compound 4 the middle estimate is 59-fold (1.77 log units) above the measured one; the measured number lies below the stated range.
By their numbers in this assay, from the lowest: compound 1; then compound 4; then compound 2. At a limit, above all of these: compound 3.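

In this assay, a 2.2-fold higher number from compound 1 to compound 4 (0.35 log units; beyond the scatter) shows that the (2-(diethylamino)ethyl)amino group is not required for activity on this carbonyl carbon. With a 91-fold lower number from compound 2 to compound 4 (1.96 log units; beyond the scatter), two tertiary carboxamides lie far apart, so the groups on the amide nitrogen matter here, not the amide alone. Replacing (but-3-yn-1-yl)oxy gives an at least 98-fold lower number from compound 3 to compound 4 (1.99 log units; beyond the scatter), a floor, as compound 3 has only a limit.

On these data alone, whether the hydroxyl of the (2-hydroxyethyl)(methyl)amino group matters stays open. So does how a carboxylic acid or a morpholine amide would read at this carbonyl carbon.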